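The source may report more compounds than this note shows. Statements on the series, on what has been measured and on what is new or still open speak of the compounds shown alone.

Measured compounds: compound 1, `CCC/N=C(\NC#N)Nc1cccnc1`, with 20 mg/kg; compound 2, `CC(C)C/N=C(\NC#N)Nc1cccnc1`, with 20 mg/kg; compound 3, `CCC(C)(C)/N=C(\NC#N)Nc1ccncc1`, with 2.5 mg/kg.

All three were tested in a functional assay on the whole organism (blood, strain Wistar-Okamoto) with Rattus norvegicus as the target, with a stated time of 5 days; a higher number here means that more compound is needed for the effect, a lower number that less compound is needed. Compound 1 and compound 2 differ by methyl in place of hydrogen on a saturated chain carbon bound to two saturated chain carbons, and the step of no change at the digits printed from compound 1 to compound 2 (within the scatter). Compound 3 carries a different core; how its core differs from the core of compound 1 is not broken down here. Compound 3 gives the lowest number of the three, and its gap to compound 1 and to compound 2 lies beyond the scatter.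

Compound 4, `CC(C)C(C)(C)/N=C(\NC#N)Nc1ccncc1`, has not been tested. It differs from compound 3 by methyl in place of hydrogen on a saturated chain carbon bound to two saturated chain carbons, the same change at the same place as in the earlier pair. Among the measured compounds shown here, that earlier step is the only guide, so the step of no change at the digits printed from compound 3 to compound 4 (within the scatter) is expected. Compound 4 is therefore expected to give 2.5 mg/kg, with a range from 1.2 mg/kg to 5 mg/kg.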

Compound 4, minimum effective dose: 20 mg/kg
Estimate against measurement, compound 4: 8.0-fold (0.90 log units) below; the measured number lies above the stated range.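

In this assay, methyl in place of hydrogen on a saturated chain carbon bound to two saturated chain carbons gives an 8.0-fold higher number from compound 3 to compound 4 (0.90 log units; beyond the scatter). The same change therefore does not carry over with the same result from one core to the other, as the two pairs show: the same change on two cores in this assay, no change at the digits printed (within the scatter) from compound 1 to compound 2 and an 8.0-fold higher number (0.90 log units; beyond the scatter) from compound 3 to compound 4, 8.0-fold (0.90 log units) apart, beyond the scatter of two such steps These two pairs do not show which feature of the cores accounts for the difference, and they give no rule for predicting the step on any further core.

The compounds shown leave open how a longer chain or a cyclopentyl group at this place would read in this assay. They also leave open whether an ethyl group in place of the added methyl would follow the same course on either core.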